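The compounds below may be only part of what the source reports. "The series", "measured", "known", "first", "only" and "open" are said of these compounds alone.

Measured compounds in an assay on isolated protein for inhibition of hexokinase-2 (Rattus norvegicus), with a stated time of 6 h, tested at 10 mM; on this read-out higher numbers stand for more inhibition at the one concentration tested (going by the name of the read-out) and lower numbers for less inhibition:

Compound 1, `O=C(CI)NCCCNc1ncnc2c1ncn2[C@@H]1O[C@H](COP(=O)(O)OP(=O)(O)OP(=O)(O)O)[C@@H](O)[C@H]1O`: 0%
Compound 2, `CN(CCCCN(C)c1ncnc2c1ncn2[C@@H]1O[C@H](COP(=O)(O)OP(=O)(O)OP(=O)(O)O)[C@@H](O)[C@H]1O)C(=O)CCCCCNC(=O)CI`: 0%
Compound 3, `O=C(CI)NCCC(=O)NCCCCCCNc1ncnc2c1ncn2[C@@H]1O[C@H](COP(=O)(O)OP(=O)(O)OP(=O)(O)O)[C@@H](O)[C@H]1O`: 0%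

All three carry the same shared core with the triphosphate and differ only in the chain that joins the core to the iodoacetamide. None of them registers in this assay; compound 1 gives 0%, compound 3 gives 0%, and compound 2 gives 0%. Compound 2 therefore stands level with compound 1 and with compound 3 at the digits recorded, and the gaps between any two of the three lie within the scatter of the measurement. No pattern of chain length against inhibition can be drawn from these three, as every chain tried so far gives the same null reading.

Compound 4, `CN(CCCCN(C)c1ncnc2c1ncn2[C@@H]1O[C@H](COP(=O)(O)OP(=O)(O)OP(=O)(O)O)[C@@H](O)[C@H]1O)C(=O)CCCNC(=O)CI`, has not yet been measured in this assay. It is compound 2 shortened by one link in the chain: ((iodomethyl)carbonyl)amino in place of 2-(((iodomethyl)carbonyl)amino)ethyl on a saturated chain carbon, three bonds along the chain from a carbonyl carbon. Given that compounds 1, 2 and 3 all give the same reading across a wide spread of chain lengths, no step beyond the scatter is expected in this assay from this shortening; the expected step is no change at the digits printed from compound 2 to compound 4 (within the scatter), in no particular direction. Compound 4 is thus estimated at 0%, with a range from -8% to 10%.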

Compound 4, a percentage reported as inhibition, at one concentration (the size of the read-out at that concentration, not a potency): 0%
Beside the measured number, compound 4's estimate shows no gap at the digits printed; low and high end bracket the measured number.
By their numbers in this assay, from the lowest: compounds 1, 2, 3 and 4 (each within the scatter of the next).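

In this assay, for the compounds shown here, the shortening gives no change at the digits printed from compound 2 to compound 4 (within the scatter), the first reading of a change made in one place only: ((iodomethyl)carbonyl)amino in place of 2-(((iodomethyl)carbonyl)amino)ethyl on a saturated chain carbon, three bonds along the chain from a carbonyl carbon. This change does not lift the reading off nil, but with compound 2 starting at 0%, the pair cannot show whether a change at this position would lower inhibition. No measurement on hand bears on the absence of a step here.

Still open, on these data alone, is whether a chloroacetamide or an acrylamide in place of the iodoacetamide, or a diphosphate in place of the triphosphate, would give any reading above nil in this assay. Also open is whether a longer chain at this position, or a primary amine or a carboxylic acid at the chain end, would change the reading, and no compound shown yet gives a reading from which the effect of a change at this position could be sized.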